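A few compounds are considered here, and "the series" means these few. Any claim that something is new, unique, unknown or untested is made for them only; others in the source may bear on it.

Series notes. Among the measured compounds shown here, in a functional assay on RPMI-8226 cells (Homo sapiens) for inhibition, read by sulforhodamine B assay, with a stated time of 48 h (on this read-out lower numbers stand for stronger inhibition of growth and higher numbers for weaker inhibition of growth), compound 1 `COc1cc(-c2cc(/C=C/C(=O)c3ccc(N)cc3)[nH]n2)cc(OC)c1OC` gives 2770 nM, the highest of the three numbers so far. Compound 2 `COc1ccc(-c2cc(/C=C/C(=O)c3ccc(OC)c(OC)c3)[nH]n2)cc1` gives 1330 nM and compound 3 `COc1ccc(-c2cc(/C=C/C(=O)c3cc(OC)c(OC)c(OC)c3)[nH]n2)cc1OC` gives 1660 nM; the gap from compound 1 to compound 3 lies within the scatter, while the gap from compound 1 to compound 2 lies just beyond it. Compound 4 `COc1ccc(C(=O)/C=C/c2cc(-c3cc(OC)c(OC)c(OC)c3)n[nH]2)cc1` has not yet been measured in this assay. It differs from compound 1 in one place: methoxy in place of amino on an aromatic carbon. For the measured compounds named here, no measured pair shows this exact change, so its size is not known from the data. Compounds 2 and 3, like compound 4, carry methoxy rather than amino on their aryl ketone, and both sit below compound 1 in this assay; on that basis a modest downward step is expected, not certainly beyond the scatter. The expected step is a 1.8-fold lower number from compound 1 to compound 4 (0.27 log units; within the scatter). For compound 4 in this assay the estimate is 1500 nM, with a range from 600 nM to 4000 nM.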

Compound 4, concentration for total growth inhibition: 2490 nM
For compound 4 the middle estimate is 1.7-fold (0.22 log units) below the measured one, within the range that was stated.
By their numbers in this assay, from the lowest: compounds 2, 3, 4 and 1 (each within the scatter of the next, the first and the last beyond it).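

Methoxy in place of amino on an aromatic carbon, para to a large group, gives a 1.1-fold lower number from compound 1 to compound 4 (0.05 log units; within the scatter) in this assay. Among the compounds shown here, this is the first single-place comparison, and it shows that 4-aminophenyl and 4-methoxyphenyl cannot be told apart at this position in this read-out, even though the amino group carries a hydrogen-bond donor and the methoxy group carries none. No measured property of these compounds bears on this result.

As far as these compounds go, whether an unsubstituted phenyl, a hydroxy group, a chlorine atom or a longer chain such as ethoxy at this position would also stay within the scatter remains open. From the compounds shown here alone, it is also open whether the same change gives a similar step on the cores of compound 2 and compound 3, which each differ from compound 4 in more than one place.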